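Aryl variation on a shared core: cytotoxicity notes

A few compounds are considered here, and "the series" means these few. Any claim that something is new, unique, unknown or untested is made for them only; others in the source may bear on it.

Measured compounds:
compound 1 `O=c1ccc2cc(OCc3cc(-c4ccccc4)no3)ccc2o1`, 53200 nM
compound 2 `O=c1ccc2cc(OCc3cc(-c4ccc(Cl)cc4)no3)ccc2o1`, "not determined" (no result reported)
compound 3 `O=c1ccc2cc(OCc3cc(-c4cccc([N+](=O)[O-])c4)no3)ccc2o1`, "not determined" (no result reported)

In a functional assay on PC-3 cells (Homo sapiens) for cytotoxicity, read by MTT assay, with a stated time of 48 h (a lower number here means a stronger inhibitor, a higher number a weaker inhibitor), compound 1 gives 53200 nM. Compound 2 gives "not determined" (no result reported) in this assay, and compound 3 gives "not determined" (no result reported). Compound 3 therefore stands without a single number in this assay; it is one of two entries in the series with no reported result, and compound 1 alone carries a figure. Among the measured compounds shown here, no step between two measured compounds can be drawn from what is in hand.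

Compound 4 `COc1ccccc1-c1cc(COc2ccc3oc(=O)ccc3c2)on1` differs from compound 3 in one place: 2-methoxyphenyl in place of 3-nitrophenyl on an aromatic carbon. Since compound 3 has no number, the only anchor for the series is compound 1, which gives 53200 nM in this assay. For the measured compounds named here, with no comparable step available, the change to compound 4 is expected to bring no shift beyond the scatter from the level set by compound 1 in this assay. Compound 4 is accordingly expected to give about 50000 nM, with a range from 15000 nM to 160000 nM.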

Compound 4, half-maximal inhibitory concentration: 22400 nM
The estimate for compound 4 lay 2.2-fold (0.35 log units) above the measured number; low and high end bracket the measured number.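

In this assay, among the compounds shown here, the replacement of methoxy for hydrogen on an aromatic carbon gives a 2.4-fold lower number from compound 1 to compound 4 (0.38 log units; beyond the scatter) and is the first readable step. It shows that the aryl group on the five-membered aromatic ring, at the carbon next to the ring nitrogen, is a place where one added group can move the number beyond the scatter, here modestly and towards a stronger inhibitor; the steps that involve compound 2 or compound 3 cannot be read, since neither carries a number, so 2-methoxyphenyl can be compared only with the plain phenyl of compound 1 and not with 3-nitrophenyl. No measurement in hand bears on the reason for this shift.

Going by these compounds, whether the shift belongs to methoxy itself or would follow any group at that place on the phenyl ring stays open, and a hydroxy group, an amine or a carboxylic acid there would test it. Compound 4 gives 22400 nM. Also open, on these data alone, is whether the series can go much further down through this aryl group alone, or whether a longer chain in place of the methoxy would take the number further in the same direction.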